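Notes on the step from compound 2 to compound 4

This account rests on a few compounds, and the source may have more. Where it says the series, first, only, none or still open, it means among the compounds named here.

In an ADME assay on microsomes from liver (Homo sapiens) for metabolic stability, read by LC-MS, with a stated time of 10 min (on this read-out lower numbers stand for a less stable compound and higher numbers for a more stable compound), compound 2 (`CN(C[C@H]1Cc2c(cccc2N2CCN(C3CC3)CC2)CN1)[C@H]1CCCc2cccnc21`) gives 15.5% and holds the higher of the two numbers available. In this assay, for the measured compounds named here, compound 3 (`CN(C[C@H]1Cc2c(cccc2N2CCN(Cc3ccccn3)CC2)CN1)[C@H]1CCCc2cccnc21`) gives 4.2% as the only other number. For compound 1 (`Cc1cnc(CN(C)C[C@H]2Cc3c(cccc3N3CCNCC3)CN2)c(C)c1`) the entry reads "not determined" (no result reported) and offers no comparison.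

Compound 4 (`C[C@@H]1CN(c2cccc3c2C[C@H](CN(C)[C@H]2CCCc4cccnc42)NC3)C[C@H](C)N1C`) is still unmeasured and differs from compound 2 by 3,4,5-trimethylpiperazin-1-yl in place of 4-cyclopropylpiperazin-1-yl on an aromatic carbon with 3,4,5-trimethylpiperazin-1-yl in place of 4-cyclopropylpiperazin-1-yl on an aromatic carbon. Going by the values given here, the single measured step that bears on this is a number 11.3 percentage points lower from compound 2 to compound 3 (beyond the scatter) with (pyridin-2-yl)methyl in place of cyclopropyl on an amine nitrogen in a ring. Among the compounds with values here, that step is modest, and it is only a loose guide, since no measured compound carries the 3,4,5-trimethylpiperazin-1-yl group.

The step expected is a number 3.5 percentage points lower from compound 2 to compound 4 (within the scatter) and it is estimated to stay within the scatter. For compound 4 the estimated value is 12% with an expected range of 4% to 28% in this estimate.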

Compound 4, percent of the compound remaining: 24.6%
Beside the measured number, compound 4's estimate is 12.6 percentage points below it; the range from low to high includes it.
By their numbers in this assay, from the lowest: compound 3; then compounds 2 and 4 (each within the scatter of the next).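

In this assay, the first change shown on the aromatic carbon gives a number 9.1 percentage points higher from compound 2 to compound 4 (within the scatter), so 3,4,5-trimethylpiperazin-1-yl can stand in place of 4-cyclopropylpiperazin-1-yl without a step beyond the scatter. The change removes the three-membered ring and adds two defined stereocentres, while the heavy-atom count stays the same. Unlike a number 11.3 percentage points lower from compound 2 to compound 3 (beyond the scatter), which lies beyond the scatter and concerns only the group on the ring amine nitrogen, this step replaces the whole piperazine substituent; nothing available accounts for the outcome of either change.

The compounds shown do not separate the contribution of the two ring methyl groups and their stereocentres from that of the methyl on the nitrogen. Going by these compounds, how 4-methylpiperazin-1-yl or a morpholine ring would read on this aromatic carbon remains open.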